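A few compounds are considered here, and "the series" means these few. Any claim that something is new, unique, unknown or untested is made for them only; others in the source may bear on it.

For the measured compounds named here, compound 1 `COc1ncc(-c2cc3c(N4C[C@@H](C)O[C@@H](C)C4)ncnc3s2)cc1NS(=O)(=O)c1ccc(F)cc1F` gives 560 nM in a functional assay on HGC-27 cells (Homo sapiens) for antiproliferative activity, read by MTT assay, with stated times of 72 h and 4 h (on this read-out higher numbers stand for weaker inhibition and lower numbers for stronger inhibition), the highest of the two numbers so far. Compound 2 `COc1ncc(-c2cc3c(N4CCC(OC)CC4)ncnc3s2)cc1NS(=O)(=O)c1ccc(F)cc1F` gives 280 nM in this assay, and the step of a 2.0-fold lower number from compound 1 to compound 2 (0.30 log units; within the scatter) sits within the scatter. Compound 3 `COc1ncc(-c2cc3c(N4CC(OC)C4)ncnc3s2)cc1NS(=O)(=O)c1ccc(F)cc1F` differs from compound 1 by 3-methoxyazetidin-1-yl in place of 2,6-dimethylmorpholin-4-yl on an aromatic carbon. Going by the values given here, the only step that bears on this change, a replacement of the group on the same aromatic carbon, is that from compound 1 to compound 2, which stayed within the scatter. For compound 3 no step beyond the scatter is therefore expected, a 1.3-fold lower number from compound 1 to compound 3 (0.12 log units; within the scatter). Compound 3 is estimated at 420 nM, in a range from 150 nM to 1200 nM.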

Compound 3, half-maximal inhibitory concentration: 830 nM
The estimate for compound 3 lay 2.0-fold (0.30 log units) below the measured number, and the stated range covers the measured number.
By their numbers in this assay, from the lowest: compounds 2, 1 and 3 (each within the scatter of the next, the first and the last beyond it).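

In this assay there is a 1.5-fold higher number from compound 1 to compound 3 (0.17 log units; within the scatter) for 3-methoxyazetidin-1-yl in place of 2,6-dimethylmorpholin-4-yl on this aromatic carbon, so this replacement does not separate the two compounds. For the compounds shown here, the comparison of the two methoxy-bearing rings gives a 3.0-fold higher number from compound 2 to compound 3 (0.47 log units; beyond the scatter) for 3-methoxyazetidin-1-yl in place of 4-methoxypiperidin-1-yl, the only one of the three steps at this position beyond the scatter, though modest in size. No evidence in hand bears on this difference.

Going by these compounds, how an open-chain dimethylamino group on the same carbon would compare remains open. So does the effect of a hydroxyl group in place of the methoxy on either ring.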